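This account rests on a few compounds, and the source may have more. Where it says the series, first, only, none or still open, it means among the compounds named here.

Compound 1 `CC(C)CCOC(=O)C(O)Cn1cnc2c(N)ncnc21`: in a functional assay on Vero cells (Chlorocebus sabaeus) for cytotoxicity (on this read-out lower numbers stand for higher toxicity in this test and higher numbers for lower toxicity in this test), compound 1 gives 400 ug/mL.
Compound 2 `CCC(C)OC(=O)C(O)Cn1cnc2c(N)ncnc21`: in this assay compound 2 gives > 400 ug/mL, which is a limit of the test rather than a number.

Compound 2 therefore stands at the limit of > 400 ug/mL in this assay, at which 1 of the 2 values shown sits. Compound 3 `CCOC(=O)C(O)Cn1cnc2c(N)ncnc21` differs from compound 2 in one place: hydrogen in place of ethyl on a saturated chain carbon bound to an oxygen next to a carbonyl group and a saturated chain carbon. For the measured compounds named here, the only measured step, a number no lower from compound 1 to compound 2 (the limit leaves the size open), also shortens the group on that oxygen and leaves the reading no lower, so the further cut to ethyl is expected to keep toxicity low, with a step of a number no higher from compound 2 to compound 3 (the limit leaves the size open) expected. Compound 3 is estimated at 400 ug/mL, between 200 ug/mL and 800 ug/mL.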

Compound 3, minimum cytotoxic concentration: > 400 ug/mL
Compound 3 was reported as a limit (the forecaster's own chance of this, stated with the estimate: 70%); the middle value sits exactly at the limit.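

A second cut to the group on that oxygen, from sec-butyl to ethyl, brings no sign of higher toxicity in this assay, so the low toxicity is not tied to the branched sec-butyl group. Measured against the isopentyl ester, the shorter chain gives a number no lower from compound 1 to compound 3 (the limit leaves the size open). The step between the two limits cannot be read, so the two shorter esters cannot be ranked: the limit of > 400 ug/mL in this assay, at which 2 of the 3 values shown sit.

As far as these compounds go, a longer chain such as octyl, or a carboxylic acid in place of the ester, remains open. Either might show whether this reading can fall further.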